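Aryl Hydrazone Variation in a Cytotoxicity Series

A few compounds are considered here, and "the series" means these few. Any claim that something is new, unique, unknown or untested is made for them only; others in the source may bear on it.

Compound 1 `COc1cc2c(Oc3ccc(NC(=O)N/N=C/c4ccc(F)cc4Cl)cc3F)ccnc2cc1OCCCN1CCCCC1`: 270 nM in a functional assay on MKN-45 cells (Homo sapiens) for cytotoxicity, read by MTT assay, with a stated time of 72 h; a lower number here means a stronger inhibitor, a higher number a weaker inhibitor.
Compound 2 `COc1cc2c(Oc3ccc(NC(=O)N/N=C/c4ccc(OC(F)(F)F)cc4)cc3F)ccnc2cc1OCCCN1CCCCC1`: 630 nM in this assay.

The two measured compounds share one core and differ only in the aryl group attached to a carbon with a double bond to nitrogen. Among the compounds with values here, compound 2 gives the highest of the two numbers, so it is the weaker inhibitor of the pair; the single measured step, a 2.3-fold higher number from compound 1 to compound 2 (0.37 log units; beyond the scatter), is modest but beyond the scatter.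

Compound 3 `COc1ccc(/C=N/NC(=O)Nc2ccc(Oc3ccnc4cc(OCCCN5CCCCC5)c(OC)cc34)c(F)c2)c(OC)c1` has not yet been measured in this assay. It differs from compound 2 in one place: 2,4-dimethoxyphenyl in place of 4-(trifluoromethoxy)phenyl on a carbon with a double bond to nitrogen. Within the data shown here, only one measured step bears on this change, a 2.3-fold higher number from compound 1 to compound 2 (0.37 log units; beyond the scatter), and it concerns a different pair of aryl groups, so it shows merely that exchanging the aryl group at this position moved the number modestly. Among the measured compounds shown here, no measured compound carries a methoxy-bearing aryl group here, so the direction is uncertain. The step from compound 2 to compound 3 is therefore expected to be small, a 1.1-fold lower number from compound 2 to compound 3 (0.02 log units; within the scatter), with no firm direction. Compound 3 is estimated at 600 nM, with a range from 200 nM to 1800 nM.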

Compound 3, half-maximal inhibitory concentration: 1990 nM
Beside the measured number, compound 3's estimate is 3.3-fold (0.52 log units) below it; measured number outside the range, above it.
By their numbers in this assay, from the lowest: compound 1; then compound 2; then compound 3.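

Swapping the aryl group on the carbon with a double bond to nitrogen can weaken the compound further than the first pair showed: in this assay, 2,4-dimethoxyphenyl in place of 4-(trifluoromethoxy)phenyl gives a 3.2-fold higher number from compound 2 to compound 3 (0.50 log units; beyond the scatter) and the change is not a neutral exchange. Set against the 2-chloro-4-fluorophenyl group, the same 2,4-dimethoxyphenyl group gives a 7.4-fold higher number from compound 1 to compound 3 (0.87 log units; beyond the scatter) and compound 3 is the weakest of the three, with both of its steps beyond the scatter. The swap to compound 3 removes the three fluorine atoms and brings in a second oxygen, but no measurement at hand explains why the number rises with this change.

Within the data shown here, with only three aryl groups compared, it remains open whether the two methoxy groups act together or whether a single methoxy group on the phenyl ring would give a similar number. As far as these compounds go, it is also open how this position would respond to quite different groups, such as an amine or a carboxylic acid on the phenyl ring, or to a plain phenyl ring with no added group.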